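Chloro in place of hydrogen on the pendant aromatic ring

The compounds below may be only part of what the source reports. "The series", "measured", "known", "first", "only" and "open" are said of these compounds alone.

Compound 1 `O=c1cc(-c2ccc(Cl)cc2)oc2cc(O)ccc12`: 143 nM
Compound 2 `O=c1cc(-c2ccc(Cl)cc2)oc2cc(OCCBr)ccc12`: 119 nM
Compound 3 `O=c1cc(-c2ccccc2)oc2cc(OCCCBr)ccc12`: 390 nM

In a functional assay for antagonist activity at Adrenergic receptor alpha-1 (Rattus norvegicus) (on this read-out higher numbers stand for weaker binding and lower numbers for tighter binding), compound 3 gives the highest number of the three, standing beyond the scatter from both compound 1 and compound 2. Compound 4 `O=c1cc(-c2ccc(Cl)cc2)oc2cc(OCCCBr)ccc12` is the unmeasured partner of compound 3, and differs from it by chloro in place of hydrogen on an aromatic carbon. Among the compounds with values here, the single measured step, a 1.2-fold lower number from compound 1 to compound 2 (0.08 log units; within the scatter), concerns the other end of the shared core and does not bear directly on this change. What the rest of the data show is that compound 2, carrying the chloro group, gives 119 nM while compound 3, carrying a plain phenyl group and a longer chain, gives 390 nM. These two differ in two places, so the share of the chloro group alone cannot be separated out. Taken together with compound 1, the two chloro compounds both sit at lower numbers than compound 3. Compound 4 is therefore expected to give a lower number, a 2.2-fold lower number from compound 3 to compound 4 (0.34 log units; beyond the scatter), with the estimate 180 nM and a range from 70 nM to 500 nM in this assay.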

Compound 4, dissociation constant: 679 nM
Compound 4: the middle estimate sits 3.8-fold (0.58 log units) below what was measured; the whole stated range lies below it.
By their numbers in this assay, from the lowest: compounds 2 and 1 (each within the scatter of the next); then compounds 3 and 4 (each within the scatter of the next).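

In this assay, within the data shown here, phenyl to 4-chlorophenyl gives the first direct reading of the chloro group, a 1.7-fold higher number from compound 3 to compound 4 (0.24 log units; within the scatter), so with the 3-bromopropyl chain in place the change cannot be told from the scatter. The larger steps now lie on the chain at the oxygen: a 5.7-fold higher number from compound 2 to compound 4 (0.76 log units; beyond the scatter) for bromomethyl in place of bromo and a 4.7-fold higher number from compound 1 to compound 4 (0.68 log units; beyond the scatter) for 3-bromopropyl in place of hydrogen, whereas a 1.2-fold lower number from compound 1 to compound 2 (0.08 log units; within the scatter) for 2-bromoethyl in place of hydrogen. Nothing at hand explains these steps.

As far as these compounds go, it remains open whether the chloro group would read the same with the 2-bromoethyl chain or the free hydroxyl. From the compounds shown here alone, it is also open whether the bromine itself matters, which an amine at the end of the chain could test.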